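A few compounds are considered here, and "the series" means these few. Any claim that something is new, unique, unknown or untested is made for them only; others in the source may bear on it.

In a toxicity assay on THLE-2 cells (Homo sapiens) for cytotoxicity, read by MTT assay, with a stated time of 72 h (on this read-out higher numbers stand for lower toxicity in this test and lower numbers for higher toxicity in this test), compound 1 (`CCOCc1sc(Nc2ncccn2)nc1-c1ccccn1`) gives 41800 nM and compound 2 (`CCOC(=O)CCc1sc(Nc2ncccn2)nc1-c1ccccn1`) gives 10500 nM on the same read-out. Compound 3 (`CCOC(=O)c1sc(Nc2ncccn2)nc1-c1cnccn1`) gives 47100 nM here, within the scatter of compound 1 and beyond the scatter above compound 2. Compound 4 (`CCOC(=O)c1sc(Nc2ncccn2)nc1-c1ccncn1`) differs from compound 3 as follows (pyrimidin-4-yl in place of pyrazin-2-yl on an aromatic carbon): pyrimidin-4-yl in place of pyrazin-2-yl on an aromatic carbon. Among the compounds with values here, the one measured step (a 4.0-fold lower number from compound 1 to compound 2 (0.60 log units; beyond the scatter)) lies beyond the scatter but concerns a saturated chain carbon, so it bears only weakly on this change. Within the data shown here, no measured step covers this exchange of rings. No step beyond the scatter is therefore expected in this assay here. The expected step (a 1.1-fold lower number from compound 3 to compound 4 (0.05 log units; within the scatter)) stays small. Compound 4 is estimated at 42000 nM with an expected range from 18000 nM to 95000 nM in this series.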

Compound 4, half-maximal cytotoxic concentration: 40800 nM
Beside the measured number, compound 4's estimate is 1.0-fold (0.01 log units) above it; the measured number falls inside the stated range.
By their numbers in this assay, from the lowest: compound 2; then compounds 4, 1 and 3 (each within the scatter of the next).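

In this assay, pyrimidin-4-yl in place of pyrazin-2-yl gives a 1.2-fold lower number from compound 3 to compound 4 (0.06 log units; within the scatter), so for this pair, moving a ring nitrogen within the six-membered ring leaves the read-out within the scatter. Within the data shown here, this is the only measured step at this position, and it holds with the ethoxycarbonyl group in place. No measurement on hand accounts for this result.

Open, going by these compounds, is whether a phenyl ring at this position would give a step beyond the scatter. Also open, on these data alone, is how a carboxylic acid in place of the ethoxycarbonyl group would read.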